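A few compounds are considered here, and "the series" means these few. Any claim that something is new, unique, unknown or untested is made for them only; others in the source may bear on it.

Measured so far:
- compound 1, `ClCc1ccc(Cn2cnc3c(Cl)ncnc32)cc1`: 410 nM
- compound 2, `ClCc1ccccc1Cn1cnc2c(Cl)nc(Cl)nc21`: 810 nM

In a functional assay on MCF7 cells (Homo sapiens) for cytotoxicity, read by sulforhodamine B assay, with a stated time of 48 h (on this read-out lower numbers stand for stronger inhibition of growth and higher numbers for weaker inhibition of growth), compound 2 gives 810 nM, the highest of the two numbers recorded. The nearest is compound 1, which in this assay gives 410 nM; the two values sit within the scatter of each other, so no order between them can be read.

The next compound, compound 3 `ClCc1ccccc1Cn1cnc2c(Cl)ncnc21`, differs from compound 2 in one place: hydrogen in place of chloro on an aromatic carbon. Going by the values given here, no step between two measured compounds covers this change, so its size is not known from the series. Among the compounds with values here, compound 1 carries the same core as compound 3 but a different benzyl substitution, and no step between compound 1 and compound 2 is available either; only their two values are there to compare.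

Within the data shown here, with no direct precedent, the step is expected to stay within the scatter, with no clear direction. Compound 3 is estimated at 700 nM, range 250 nM to 2000 nM, which corresponds to an expected step of a 1.2-fold lower number from compound 2 to compound 3 (0.06 log units; within the scatter).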

Compound 3, concentration for 50% growth inhibition: 11000 nM
Compound 3: the middle estimate sits 16-fold (1.20 log units) below what was measured, and the stated range ends below it.
By their numbers in this assay, from the lowest: compounds 1 and 2 (each within the scatter of the next); then compound 3.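

In this assay, going by these compounds alone, the chloro group on the aromatic carbon between two ring nitrogen atoms proves to be far from a silent substituent: replacing it with hydrogen gives a 14-fold higher number from compound 2 to compound 3 (1.13 log units; beyond the scatter), the first step that can be read from a single change. The other chloro group, meta to this position, and the benzyl substitution are the same in both compounds, so the whole step belongs to this one position. The compounds shown offer no measurement that could explain the size of this step.

As far as these compounds go, only chloro and hydrogen have been seen at this position, so it remains open whether an amine, a methoxy group or a bromo group would stay near compound 2 or fall toward compound 3. From the compounds shown here alone, it also remains open whether the chloro group at this position would carry the same weight alongside the benzyl substitution of compound 1, and whether the step extends to other cell lines.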